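Working notes: the step from compound 1 to compound 3

The source may hold more compounds than are shown below. What is called first, only, known or untested is meant among the compounds shown, and "the series" means these compounds.

Compound 1 `CC(C)N1CCN(CCCN(C[C@H]2Cc3ccccc3CN2)[C@H]2CCCc3cccnc32)CC1`: 344 nm/s
Compound 2 `c1cnc2c(c1)CCC[C@@H]2N(CCCN1CCNCC1)Cc1nc2ccccc2s1`: "not determined" (no result reported)

For the measured compounds named here, in an ADME assay for permeability, using PAMPA, with a stated time of 4 h, at pH 7.4 (a lower number here means that the compound crosses the layer more slowly, a higher number that the compound crosses the layer faster), compound 1 gives 344 nm/s, the only number available, so its standing relative to other compounds cannot be judged. Compound 2 has no result and offers no comparison. Compound 3 `c1ccc2c(c1)CN[C@@H](CN(CC[C@H]1CCCNC1)[C@H]1CCCc3cccnc31)C2` is still to be measured. Its structure departs from compound 1 in one place: piperidin-3-yl in place of (4-isopropylpiperazin-1-yl)methyl on a saturated chain carbon, two bonds along the chain from an amine nitrogen. Cut one bond further out, the same difference reads 2-(4-isopropylpiperazin-1-yl)ethyl to (piperidin-3-yl)methyl. Going by the values given here, no measured pair gauges such a change, so the expectation rests only on compound 1 at 344 nm/s and the structural difference, and it is weakly founded. A moderate downward move is expected in this assay, estimated as a 2.3-fold lower number from compound 1 to compound 3 (0.36 log units; beyond the scatter). For compound 3 the estimated value is 150 nm/s, with an expected range of 35 nm/s to 500 nm/s.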

Compound 3, apparent permeability: 55 nm/s
Estimate against measurement, compound 3: 2.7-fold (0.44 log units) above; the range from low to high includes it.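

In this assay, for the compounds shown here, this position proves sensitive to the group it carries: piperidin-3-yl in place of (4-isopropylpiperazin-1-yl)methyl gives a 6.3-fold lower number from compound 1 to compound 3 (0.80 log units; beyond the scatter) in the first step that can be read. The entering group has 6 heavy atoms and 1 hydrogen-bond donor, while the leaving group has 10 heavy atoms and 0 hydrogen-bond donors, so this single step changes size and donor count together and cannot separate them. No supporting data bear on why the number falls.

Open, as far as these compounds go, is whether the lower number follows the donor count or the size of the group. A 1-isopropylpiperidin-3-yl group or a 1-methylpiperidin-3-yl group on the same chain carbon would pull these two differences apart.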